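Amide swap from compound 3 to compound 4

A few compounds are considered here, and "the series" means these few. Any claim that something is new, unique, unknown or untested is made for them only; others in the source may bear on it.

In a functional assay on HCT-116 cells (Homo sapiens) for antiproliferative activity, read by MTT assay, with a stated time of 72 h (on this read-out higher numbers stand for weaker inhibition and lower numbers for stronger inhibition), compound 1 (`Cc1noc(C)c1-c1nn(Cc2ccc(C(=O)NC3CC3)cc2)c(=O)c2ccccc12`) gives > 100000 nM as a limit of the assay. In this assay compound 3 (`Cc1noc(C)c1-c1nn(Cc2ccc(C(=O)NC3CCN(C)CC3)cc2)c(=O)c2ccccc12`) reads 84900 nM and holds the higher of the two actual numbers. Compound 2 (`Cn1cc(-c2nn(Cc3ccc(C(=O)NC4CCCC4)cc3)c(=O)c3ccccc23)cn1`) reads 14300 nM as the other number, lower by more than the scatter.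

The next change leads to compound 4 (`Cc1noc(C)c1-c1nn(Cc2ccc(C(=O)NC3CCCC3)cc2)c(=O)c2ccccc12`), with cyclopentyl in place of 1-methylpiperidin-4-yl on an amide-type nitrogen. The rest of the structure stays as in compound 3.

Within the data shown here, one measured step touches this nitrogen. Replacing cyclopropyl with 1-methylpiperidin-4-yl gave an at least 1.1-fold lower number from compound 1 to compound 3 (0.07 log units; that floor lies within the scatter) and, as a floor, it bounds the size from one side only. That step therefore sets no clear size for the change at hand.

The other guide is indirect: cyclopentyl already stands on the amide of compound 2 at 14300 nM with a different group elsewhere on the core. On that reading, a move toward a lower number is expected, estimated as a 2.4-fold lower number from compound 3 to compound 4 (0.38 log units; beyond the scatter) and modest in size. In this assay the expected value for compound 4 is 35000 nM (estimated range 12000 nM to 100000 nM).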

Compound 4, half-maximal inhibitory concentration: > 100000 nM
Compound 4: a limit, no number (the forecaster's own chance of this, stated with the estimate: 15%); middle value at least 2.8-fold (0.45 log units) away from the limit.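

In this assay compound 4 gives > 100000 nM, which is a limit of the assay and not a number. With 3,5-dimethyl-1,2-oxazol-4-yl kept on the core, placing cyclopentyl on the amide-type nitrogen in place of 1-methylpiperidin-4-yl brings no gain: the step reads an at least 1.1-fold higher number from compound 3 to compound 4 (0.07 log units; that floor lies within the scatter). With cyclopentyl held constant on the amide, the group on the aromatic carbon now stands out as a clear site of change, since 3,5-dimethyl-1,2-oxazol-4-yl in place of 1-methyl-1H-pyrazol-4-yl gives an at least 6.9-fold higher number from compound 2 to compound 4 (0.84 log units; beyond the scatter), so the activity seen with cyclopentyl on the amide depends on the group at that carbon.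

Steps with a limit at both ends cannot be read, and the true effect of the amide groups on this core stays bounded from one side only, because the values pile up at the top of the range: the limit of > 100000 nM in this assay, at which 2 of the 4 values shown sit. Still open is whether 1-methyl-1H-pyrazol-4-yl on the core would pair better with 1-methylpiperidin-4-yl or cyclopropyl on the amide, and whether a carboxylic acid, a primary amine or a longer alkyl chain at that nitrogen would give a number clear of the limit.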